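Swapping one substituent: the step to compound 3

The compounds below may be only part of what the source reports. "The series", "measured", "known", "first", "only" and "open" are said of these compounds alone.

Measured in an ADME assay (liver) for metabolic stability, with Liver microsome (Homo sapiens) as the target, using microsomes and NADPH, with a stated time of 30 min, tested at 1 uM; on this read-out lower numbers stand for slow clearance and higher numbers for fast clearance:
compound 1 `CC(C)n1cc(-c2cc(C(O)(C(F)(F)F)C(F)(F)F)cnc2N2CCN(S(=O)(=O)c3ccc(N)nc3)CC2)cn1` | 38 mL.min-1.g-1
compound 2 `CC(C)(C)n1cc(-c2cc(C(O)(C(F)(F)F)C(F)(F)F)cnc2N2CCN(S(=O)(=O)c3ccc(N)nc3)CC2)cn1` | 86 mL.min-1.g-1

Of these two compounds, compound 2 has the higher number, at 86 mL.min-1.g-1 on this read-out. Compound 3 `Nc1ccc(S(=O)(=O)N2CCN(c3ncc(C(O)(C(F)(F)F)C(F)(F)F)cc3-c3ccoc3)CC2)cn1` carries furan-3-yl in place of 1-(tert-butyl)-1H-pyrazol-4-yl on an aromatic carbon. Within the data shown here, only one measured step bears on this change. It is a 2.3-fold higher number from compound 1 to compound 2 (0.35 log units; beyond the scatter) and it is modest, arising within the same substituent. Among the measured compounds shown here, no measured compound carries furan-3-yl, so the evidence is thin. Compound 3 no longer has the tert-butyl group of compound 2, and that step alone suggests a modest fall in this assay with wide uncertainty. The expected change is a 1.7-fold lower number from compound 2 to compound 3 (0.24 log units; within the scatter) in this estimate. For compound 3 the estimated value is 50 mL.min-1.g-1 with an expected range from 20 mL.min-1.g-1 to 120 mL.min-1.g-1 in the same assay.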

Compound 3, intrinsic clearance in microsomes: < 14 mL.min-1.g-1
Compound 3: only a limit was reported (the forecaster's own chance of this, stated with the estimate: 3%); middle value at least 3.5-fold (0.55 log units) away from the limit.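

The earlier compounds shown here varied only the alkyl group on the pyrazole, whereas exchanging the whole substituent on this aromatic carbon shows that the read-out in this assay can also fall, with an at least 6.1-fold lower number from compound 2 to compound 3 (0.78 log units; beyond the scatter). This fall is not tied to the tert-butyl group alone, as the 1-isopropyl-1H-pyrazol-4-yl substituent points the same way, with an at least 2.7-fold lower number from compound 1 to compound 3 (0.43 log units; beyond the scatter). The reading for compound 3 is a limit of the assay and not a number, so the full size of both steps stays open: the limit of < 14 mL.min-1.g-1 in this assay, at which 1 of the 3 values shown sits.

The compounds shown do not separate the effect of the furan ring from the loss of the alkyl group on the pyrazole. From the compounds shown here alone, whether a pyrazole carrying only a hydrogen or a methyl on its nitrogen, or a phenyl ring on this carbon, would read as low also remains open.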